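The compounds below may be only part of what the source reports. "The series", "measured", "known", "first", "only" and "open" are said of these compounds alone.

Measured so far in an assay on isolated protein for inhibition of sphingosine kinase 1 (Homo sapiens); on this read-out lower numbers stand for stronger inhibition and higher numbers for weaker inhibition:

compound 1 `CCCCCCCc1cc(-c2ccc(CNC(=O)[C@H]3NCC[C@@H]3O)cc2)n[nH]1`: 1100 nM
compound 2 `CC[C@H](NC(=O)[C@H]1NCC[C@@H]1O)c1ccc(-c2noc(CCC3CCCC3)n2)cc1`: 56 nM
compound 3 `CCCCCCCc1nc(-c2ccc([C@@H](NC(=O)[C@H]3NCC[C@@H]3O)C(C)C)cc2)no1`: 110 nM

Compound 3 holds the second highest of the three numbers. Compound 2, with its value of 56 nM, is the nearest to it, and the two values sit within the scatter of each other, so nothing can be read from their order. Compound 1, whose number is the furthest away, gives 1100 nM, a gap that lies beyond the scatter.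

Compound 4 `CCCCCCCc1nc(-c2ccc([C@H](CC)NC(=O)[C@H]3NCC[C@@H]3O)cc2)no1` has not yet been measured. It differs from compound 3 by hydrogen in place of methyl on a saturated chain carbon bound to two saturated chain carbons. Within the data shown here, no pair of measured compounds shares exactly this difference, so there is no step to lean on. Compound 2 also carries an ethyl at the corresponding chain carbon, and its value of 56 nM lies within the scatter of the value of compound 3, which suggests that the shortening carries no large effect on its own.

The expectation for the step from compound 3 to compound 4 is therefore a 1.4-fold lower number from compound 3 to compound 4 (0.14 log units; within the scatter), with either direction possible and nothing clearly beyond the scatter. Compound 4 is estimated at 80 nM, within a range from 30 nM to 220 nM.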

Compound 4, half-maximal inhibitory concentration in the sphingosine kinase 1 assay: 30 nM
The estimate for compound 4 lay 2.7-fold (0.43 log units) above the measured number, and the stated range covers the measured number.
By their numbers in the sphingosine kinase 1 assay, from the lowest: compounds 4, 2 and 3 (each within the scatter of the next, the first and the last beyond it); then compound 1.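

Among these compounds, in the sphingosine kinase 1 assay, isopropyl to ethyl on this saturated chain carbon gives a 3.7-fold lower number from compound 3 to compound 4 (0.56 log units; beyond the scatter), the first direct reading at this position, and it lies beyond the scatter. With the ethyl held constant, the sphingosine kinase 1 assay gives a 1.9-fold lower number from compound 2 to compound 4 (0.27 log units; within the scatter) for pentyl in place of cyclopentyl on a saturated chain carbon, two bonds along the chain from an aromatic carbon, so these two end groups cannot be told apart on this read-out. In a physicochemical assay for solubility, at pH 7.4 (a lower number here means a less soluble compound, a higher number a more soluble compound), compound 3 gives 3 ug/mL and compound 4 gives 9 ug/mL. The isopropyl to ethyl change also goes with a higher number in the physicochemical assay, so for this pair the lower inhibition number does not come at the cost of a lower solubility number: the measured solubility of compound 3, 3 ug/mL, and of compound 4, 9 ug/mL, a 3.0-fold higher number (0.48 log units; beyond the scatter)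

Open, as far as these compounds go, is how a methyl or a cyclopropyl on this chain carbon would read in the sphingosine kinase 1 assay and in the physicochemical assay, and so whether the gain continues as the group shrinks or depends on this particular ethyl. Also open, from the compounds shown here alone, is whether isopropyl to ethyl gives a step of similar size with the cyclopentyl end group of compound 2 in place.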